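A Swap on the Phenyl Borne by the Ring Nitrogen

The source may report more compounds than this note shows. Statements on the series, on what has been measured and on what is new or still open speak of the compounds shown alone.

Three compounds share one core and differ only in the phenyl attached to an aromatic nitrogen. Compound 1 `O=C(Nc1cccc(OCc2cn(-c3ccccc3)nn2)c1)Nc1ccc(Cl)c(C(F)(F)F)c1` gives 1780 nM in a functional assay on HepG2 cells (Homo sapiens) for inhibition, read by MTT assay, with a stated time of 72 h; a lower number here means a stronger inhibitor, a higher number a weaker inhibitor. Compound 2 `O=C(Nc1cccc(OCc2cn(-c3cccc(F)c3)nn2)c1)Nc1ccc(Cl)c(C(F)(F)F)c1` gives 2120 nM, and compound 3 `O=C(Nc1cccc(OCc2cn(-c3ccccc3Cl)nn2)c1)Nc1ccc(Cl)c(C(F)(F)F)c1` gives 1960 nM. Compound 3 stands second highest of the three numbers, yet its gap to either neighbour is within the scatter, so the three read as one level. The steps that reach it are small: a 1.2-fold higher number from compound 1 to compound 2 (0.08 log units; within the scatter), a 1.1-fold higher number from compound 1 to compound 3 (0.04 log units; within the scatter), and a 1.1-fold lower number from compound 2 to compound 3 (0.03 log units; within the scatter).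

Compound 4 `O=C(Nc1cccc(OCc2cn(-c3ccc(I)cc3)nn2)c1)Nc1ccc(Cl)c(C(F)(F)F)c1` continues the series with the change (4-iodophenyl in place of 2-chlorophenyl on an aromatic nitrogen). All three measured steps alter the same phenyl and none moved the number beyond the scatter, so the same is expected here: an estimated step of a 1.0-fold higher number from compound 3 to compound 4 (0.01 log units; within the scatter) in this assay, with no direction favoured. Compound 4 is therefore expected to give about 2000 nM, within a range of 1000 nM to 4200 nM.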

Compound 4, half-maximal inhibitory concentration: 2690 nM
Compound 4: the middle estimate sits 1.3-fold (0.13 log units) below what was measured; low and high end bracket the measured number.
By their numbers in this assay, from the lowest: compounds 1, 3, 2 and 4 (each within the scatter of the next).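

In this assay, the change to 4-iodophenyl on the aromatic nitrogen gives a 1.4-fold higher number from compound 3 to compound 4 (0.14 log units; within the scatter), a 1.3-fold higher number from compound 2 to compound 4 (0.10 log units; within the scatter) and a 1.5-fold higher number from compound 1 to compound 4 (0.18 log units; within the scatter), so the four compounds still read as one level. Iodo thus joins fluoro and chloro as a halogen on this phenyl that leaves the number within the scatter of the unsubstituted phenyl, and the 2-chlorophenyl, 3-fluorophenyl and 4-iodophenyl groups together show no dependence on which halogen is present or where it sits, although each halogen appears at only one place. Nothing available explains this flat response.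

Going by these compounds, it remains open whether an amine, a carboxylic acid or a methoxy group on this phenyl would move the number. On these data alone, it is equally open whether a longer chain in place of the phenyl would leave this level intact.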